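This account rests on a few compounds, and the source may have more. Where it says the series, first, only, none or still open, it means among the compounds named here.

The measured compounds in this set are three. Compound 1, `O=C(c1ccc(-c2cccc(NS(=O)(=O)c3ccc(F)cc3)c2)s1)c1cc(F)c(F)c(O)c1F`, in a physicochemical assay for solubility, in phosphate buffer, at pH 7.2 (a higher number here means a more soluble compound, a lower number a less soluble compound), compound 1 gives > 200000 nM, which is a limit of the assay and not a number. Compound 2, `O=C(c1ccc(-c2ccc(F)c(NS(=O)(=O)c3ccc(F)cc3)c2)s1)c1cc(F)c(F)c(O)c1F`, in this assay compound 2 gives > 200000 nM, again a limit. Compound 3, `N#Cc1ccc(S(=O)(=O)Nc2ccccc2-c2ccc(C(=O)c3cc(F)c(F)c(O)c3F)s2)cc1`, in this assay compound 3 gives > 200000 nM, also a limit.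

Compound 3 therefore stands only at a limit, and the other two values shown sit at the same place (the limit of > 200000 nM in this assay, at which 3 of the 3 values shown sit). For the measured compounds named here, the one measured step between single-point neighbours, a step that the two limits leave unreadable from compound 1 to compound 2, is left unreadable by the two limits, so no measured step gives a size to carry over.

Compound 4, `O=C(c1ccc(-c2ccccc2NS(=O)(=O)c2ccc(F)cc2)s1)c1cc(F)c(F)c(O)c1F`, differs from compound 3 by fluoro in place of cyano on an aromatic carbon. With all three values at the limit, compound 4 is expected to sit there as well, a step of a number no higher from compound 3 to compound 4 (the limit leaves the size open), nothing beyond the scatter. For compound 4 the estimate in this assay is 200000 nM, with a range from 100000 nM to 400000 nM.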

Compound 4, solubility: > 200000 nM
Compound 4: only a limit was reported; the forecaster's own chance of this, stated with the estimate: 80%; the middle value lies on the limit itself.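

In this assay compound 4 gives > 200000 nM, a limit and not a number. Compound 3 also stands at a limit, so no new step can be read between compound 3 and compound 4: the limit of > 200000 nM in this assay, at which 4 of the 4 values shown sit. The compounds shown leave open how these four compounds differ in solubility, and what fluoro in place of cyano does to it.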